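The compounds below may be only part of what the source reports. "The series", "measured", "known", "first", "only" and "open" are said of these compounds alone.

Measured so far:
Compound 1, `CC(=O)c1ccc(NC(=O)C2CC(O)CN2S(=O)(=O)c2ccc(C)cc2)cc1`: 12.4%
Compound 2, `CC(=O)c1ccc(NC(=O)CN(C(=O)c2ccccc2)S(=O)(=O)c2ccc([N+](=O)[O-])cc2)cc1`: 20.6%

The read-out is a functional assay for inhibition, read by spectrophotometry, with a stated time of 20 min, tested at 1 mg/mL; a lower number here means a weaker effect, a higher number a stronger effect of the compound at the concentration tested. In this assay compound 1 gives 12.4%. Among the measured compounds shown here, only one other number stands beside it: compound 2 gives 20.6%, and the gap between the two lies within the usual scatter of repeated measurements, so the two numbers cannot be told apart. Compound 1 is therefore one of a pair of weak results, with nothing that sets it apart from compound 2.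

Compound 3, `CC(=O)c1ccc(NC(=O)C2CC(O)CN2S(=O)(=O)c2ccc([N+](=O)[O-])cc2)cc1`, has not yet been measured. It differs from compound 1 in one place: nitro in place of methyl on an aromatic carbon. For the measured compounds named here, compound 2 also carries a nitro on its phenyl, but its remaining structure differs from compound 1 in several other places, so no step that isolates this single change is available. Without such a step, the expectation rests on the weak result of compound 1 alone. Compound 3 is expected to give about 16%, between 5% and 30%. The expected step of a number 3.6 percentage points higher from compound 1 to compound 3 (within the scatter) is small, not beyond the scatter.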

Compound 3, a percentage reported as inhibition, at one concentration (the size of the read-out at that concentration, not a potency): 43.2%
Compound 3: the middle estimate sits 27.2 percentage points below what was measured, outside the stated range (above it).
By their numbers in this assay, from the lowest: compounds 1 and 2 (each within the scatter of the next); then compound 3.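

In this assay, nitro in place of methyl on the aromatic carbon para to a large group gives a number 30.8 percentage points higher from compound 1 to compound 3 (beyond the scatter). Among the compounds shown here, this is the first change here that can be read on its own, and it shows that the result depends on what sits at this position of the shared core: the earlier pair, compound 1 and compound 2, differ in several places and could not be told apart. The data offer no measurement that explains why this swap matters.

As far as these compounds go, this single pair shows only that 4-nitrophenyl gives a stronger effect than 4-methylphenyl on this core, so it remains open whether nitro is special or whether other groups at this position, such as an amine, a carboxylic acid or a chlorine, would do as well. From the compounds shown here alone, each result is also a size of effect at one concentration rather than a potency, so how far compound 3 outperforms compound 1 at other concentrations also remains open.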